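Same Small Change, Second Core

The compounds below may be only part of what the source reports. "The series", "measured", "known", "first", "only" and "open" are said of these compounds alone.

Measured so far:
compound 1 `N/C(=N\NC(=S)N1CCCCCC1)c1ccccn1` gives 21.3%
compound 2 `N/C(=N\NC(=S)N1CCOCC1)c1ccccn1` gives 12.7%
compound 3 `N/C(=N\NC(=S)N1CCOCC1)c1ccc(F)cn1` gives 21.4%

All three were tested in a functional assay on HeLa cells (Homo sapiens) for cytotoxicity, read by MTT assay, with a stated time of 72 h, tested at 1 uM; on this read-out lower numbers stand for less inhibition of growth and higher numbers for more inhibition of growth at the one concentration tested. Compound 1 and compound 2 share no single counted difference; how their two cores differ is not broken down here. Compound 3 arises from compound 2 by one change, (fluoro in place of hydrogen on an aromatic carbon), and this change made a step of a number 8.7 percentage points higher from compound 2 to compound 3 (within the scatter). Compound 4 `N/C(=N\NC(=S)N1CCCCCC1)c1ccc(F)cn1` is not yet measured. It arises from compound 1 by the same change, (fluoro in place of hydrogen on an aromatic carbon), at the same place on the ring.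

Because compound 2 to compound 3 showed a number 8.7 percentage points higher from compound 2 to compound 3 (within the scatter), the step from compound 1 to compound 4 is expected to be of a similar size, a number 6.7 percentage points higher from compound 1 to compound 4 (within the scatter). On that basis compound 4 is estimated at 28%, with a range from 14% to 42%.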

Compound 4, percent growth inhibition at one concentration: 50%
Compound 4: the middle estimate sits 22 percentage points below what was measured; measured number above the stated range.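

In this assay, fluoro in place of hydrogen on an aromatic carbon gave a step of a number 28.7 percentage points higher from compound 1 to compound 4 (beyond the scatter). Set side by side, the two steps differ in size, so in this series the change did not carry over from one core to the other as a fixed amount: the same change on two cores in this assay, a number 8.7 percentage points higher (within the scatter) from compound 2 to compound 3 and a number 28.7 percentage points higher (beyond the scatter) from compound 1 to compound 4, 20 percentage points apart, beyond the scatter of two such steps. This shows that the size of the step differs between these two cores, but it does not show why, and two pairs give no rule for predicting the step on any other core.

The compounds shown leave open whether a chlorine atom or an amine at the same place would also give steps that differ between these two cores. From the compounds shown here alone, how large the fluoro step would be on a third core also remains open.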